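This account rests on a few compounds, and the source may have more. Where it says the series, first, only, none or still open, it means among the compounds named here.

Working notes on the series. The shared core of compound 1 `CCOc1cccc(-c2ccc([C@H]3S[C@@H](C)C(=O)Nc4c3c(C)nn4-c3ccccc3C)cc2)c1` carries a 3-ethoxyphenyl group; in an assay on isolated protein for agonist activity at Bile acid receptor (Homo sapiens), read by AlphaScreen, with a stated time of 30 min (on this read-out lower numbers stand for smaller maximal responses and higher numbers for larger maximal responses), compound 1 gives 13%. Compound 2 `Cc1cccc(-n2nc(C)c3c2NC(=O)[C@H](C)S[C@@H]3c2ccc(Oc3ccccc3)cc2)c1` differs at more than one place and gives 22% in this assay. Of the two numbers, compound 1 has the lowest, with compound 2 the nearest, but the gap lies within the usual scatter, so no order between the two can be stated. Compound 3 `Cc1ccccc1-n1nc(C)c2c1NC(=O)[C@H](C)S[C@@H]2c1ccc(-c2ccco2)cc1` has not yet been measured. It differs from compound 1 in one place: furan-2-yl in place of 3-ethoxyphenyl on an aromatic carbon. For the measured compounds named here, no measured pair isolates this change, so only the two low maximal responses already seen can guide expectation. The step from compound 1 to compound 3 is expected to be small, a number 5 percentage points higher from compound 1 to compound 3 (within the scatter), most likely none beyond the scatter. Compound 3 is therefore estimated at 18%, within a range of 5% to 35%.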

Compound 3, largest response reached (reported as efficacy), in percent of the reference or control that the assay uses: 32%
Estimate against measurement, compound 3: 14 percentage points below, within the range that was stated.
By their numbers in this assay, from the lowest: compounds 1, 2 and 3 (each within the scatter of the next, the first and the last beyond it).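

For the compounds shown here, this is the first readable step at this position. In this assay furan-2-yl in place of 3-ethoxyphenyl, on an aromatic carbon para to a large group, gives a number 19 percentage points higher from compound 1 to compound 3 (beyond the scatter) so the maximal response here depends on the group carried at this place. The two groups have the same counts of hydrogen-bond donors and acceptors and no net charge, so those counts do not separate them, while ring type and heavy-atom count do differ; nothing measured here accounts for the step.

A single step cannot show whether the five-membered ring or the loss of the ethoxy group matters more, which unsubstituted phenyl or thiophen-2-yl at this place could separate. Going by these compounds, how an amine or a carboxylic acid on this ring would behave also remains open.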